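The source may report more compounds than this note shows. Statements on the series, on what has been measured and on what is new or still open speak of the compounds shown alone.

The series shares one core, carried by compound 1 `CCC(C)c1cc(C)c(C(=O)N=C(N)N)cc1S(C)(=O)=O` and compound 2 `CSc1cc(C)c(C(=O)N=C(N)N)cc1S(C)(=O)=O`. In a functional assay for inhibition of sodium/hydrogen exchanger (Oryctolagus cuniculus) (a lower number here means a stronger inhibitor, a higher number a weaker inhibitor), compound 1 gives 8 nM, and in this assay compound 2 gives 6 nM. Among the measured compounds shown here, the step of a 1.3-fold lower number from compound 1 to compound 2 (0.12 log units; within the scatter) is the only measured step so far, and it stays within the scatter. Compound 2 thus stands lowest of the two numbers, with compound 1 nearest and the gap within the scatter, so no order between the two can be read.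

Compound 3 `CCSc1cc(C)c(C(=O)N=C(N)N)cc1S(C)(=O)=O` has not yet been measured in this assay. It differs from compound 2 by methyl in place of hydrogen on a saturated chain carbon bound to a sulfur, which reads, one bond further out, as methylsulfanyl to ethylsulfanyl. For the measured compounds named here, the only measured step, a 1.3-fold lower number from compound 1 to compound 2 (0.12 log units; within the scatter), exchanged a whole sec-butyl group for methylsulfanyl without moving beyond the scatter. Going by the values given here, because that step a 1.3-fold lower number from compound 1 to compound 2 (0.12 log units; within the scatter) was within the scatter, the single added methyl in compound 3 is expected to give a step of no change at the digits printed from compound 2 to compound 3 (within the scatter) that also stays within the scatter, in no particular direction. Compound 3 is therefore estimated to give 6 nM in this assay, with a range from 3 nM to 14 nM.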

Compound 3, half-maximal inhibitory concentration: 5.9 nM
Compound 3: middle estimate off by 1.0-fold (0.01 log units), on the high side; low and high end bracket the measured number.
By their numbers in this assay, from the lowest: compounds 3, 2 and 1 (each within the scatter of the next).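

In this assay, extending methylsulfanyl to ethylsulfanyl gives a 1.0-fold lower number from compound 2 to compound 3 (0.01 log units; within the scatter), so the added methyl on a saturated chain carbon bound to a sulfur separates neither the numbers nor the two groups. The larger exchange of sec-butyl for ethylsulfanyl on an aromatic carbon gives a 1.4-fold lower number from compound 1 to compound 3 (0.13 log units; within the scatter), which, read with a 1.3-fold lower number from compound 1 to compound 2 (0.12 log units; within the scatter), puts all three groups at this position within the scatter of one another, with no order among them in this assay. No available measurement bears on why these three numbers stay together.

The three groups at this position leave open whether the same flat reading would hold for a longer chain such as n-butylsulfanyl, or for a quite different group there, such as an amine or a carboxylic acid. The rest of the shared core is identical in compounds 1, 2 and 3, so these numbers say nothing about how sensitive this assay is to a change anywhere else on it, including the methyl or the methylsulfonyl group.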